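The source may report more compounds than this note shows. Statements on the series, on what has been measured and on what is new or still open speak of the compounds shown alone.

Three compounds share one core. In an assay for binding affinity to Alpha-1B adrenergic receptor (Homo sapiens) (on this read-out higher numbers stand for weaker inhibition and lower numbers for stronger inhibition), compound 1 `O=c1c2ccccc2c(Cc2ccc(Cl)cc2)nn1CCNCCCCc1ccc(OCCCN2CCCCCC2)cc1` gives 316 nM, and compound 3 `O=c1c2ccccc2c(Cc2ccc(Cl)cc2)nn1C1CCCN(Cc2ccc(OCCCN3CCCCCC3)cc2)CC1` gives 126 nM. Compound 2 `CN1CCC[C@@H]1Cn1nc(Cc2ccc(O)cc2)c2ccccc2c1=O` gives 398 nM, the highest of the three numbers; its gap to compound 1 lies within the scatter, while compound 3 lies beyond it. Compound 4 `CN1CCC[C@@H]1Cn1nc(Cc2cccc(Cl)c2)c2ccccc2c1=O` has not yet been measured. It differs from compound 2 by 3-chlorophenyl in place of 4-hydroxyphenyl on a saturated chain carbon bound to an aromatic carbon. Within the data shown here, no measured pair shows this exact change, so the expectation is rough. Compounds 1 and 3 carry chlorine rather than a hydroxyl on that ring, and compound 3 in particular gives a lower number than compound 2, so a small step toward a lower number, or none beyond the scatter, is expected. Compound 4 is therefore estimated at 300 nM, with a likely range from 100 nM to 1000 nM, which would mean an expected step of a 1.3-fold lower number from compound 2 to compound 4 (0.12 log units; within the scatter).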

Compound 4, inhibition constant: 631 nM
Estimate against measurement, compound 4: 2.1-fold (0.32 log units) below, within the range that was stated.
By their numbers in this assay, from the lowest: compound 3; then compounds 1, 2 and 4 (each within the scatter of the next).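

In this assay, among these compounds, this is the first pair of compounds that differ only at this position, and the step is a 1.6-fold higher number from compound 2 to compound 4 (0.20 log units; within the scatter). Putting 3-chlorophenyl in place of 4-hydroxyphenyl on this saturated chain carbon removes the hydrogen-bond donor and acceptor of the leaving group, yet it produces no change that can be told apart from the scatter. No measurement here bears on why this is so.

This change alters both the ring's substituent and where it sits, so the two cannot be separated. On these data alone, a 3-hydroxyphenyl or an unsubstituted phenyl on that carbon would address this question, and its outcome remains open.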